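The source may hold more compounds than are shown below. What is called first, only, known or untested is meant among the compounds shown, and "the series" means these compounds.

In a functional assay on DWD cells (Homo sapiens) for inhibition, read by sulforhodamine B assay (on this read-out higher numbers stand for weaker inhibition of growth and lower numbers for stronger inhibition of growth), compound 1 `FC(F)(F)c1ccc(-c2ccc(-c3ccc(-c4nc5ccccc5[nH]4)cc3)cc2)cc1` gives 100000 nM and compound 3 `COc1ccc(-c2ccc(-c3ccc(-c4nc5ccccc5[nH]4)cc3)cc2)cc1` gives 100000 nM, with no change at the digits printed from compound 1 to compound 3 (within the scatter). Only compound 2 `Oc1ccc(-c2ccc(-c3ccc(-c4nc5ccccc5[nH]4)cc3)cc2)cc1` differs from them, at 46300 nM. Compound 4 `Oc1cccc2[nH]c(-c3ccc(-c4ccc(-c5ccc(C(F)(F)F)cc5)cc4)cc3)nc12` keeps the core of compound 1 but has hydroxy in place of hydrogen on an aromatic carbon, hydroxy in place of hydrogen on an aromatic carbon, so 1H-benzimidazol-2-yl becomes 4-hydroxy-1H-benzimidazol-2-yl. Among the measured compounds shown here, no measured step changes this part of the molecule, so the guidance is indirect. Hydroxy in place of trifluoromethyl gave a 2.2-fold lower number from compound 1 to compound 2 (0.33 log units; beyond the scatter), and methylating that hydroxy gave a 2.2-fold higher number from compound 2 to compound 3 (0.33 log units; beyond the scatter). Both steps are modest, so a similarly modest move to a lower number is expected, namely a 2.2-fold lower number from compound 1 to compound 4 (0.35 log units; beyond the scatter). For compound 4 the estimated value is 45000 nM, within an expected range of 12000 nM to 100000 nM.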

Compound 4, concentration for 50% growth inhibition: 3180 nM
Compound 4: the middle estimate sits 14-fold (1.15 log units) above what was measured; measured number outside the range, below it.
By their numbers in this assay, from the lowest: compound 4; then compound 2; then compounds 1 and 3 (each within the scatter of the next).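

Adding hydroxy to the 1H-benzimidazol-2-yl group gives a 31-fold lower number from compound 1 to compound 4 (1.50 log units; beyond the scatter) in this assay. This shows that this part of the molecule can move the number far more than the changes at the trifluoromethyl end seen among compounds 1, 2 and 3. No measurement here accounts for the size of this step.

On these data alone, it remains open whether the effect needs hydroxy itself, which an amine or a methoxy at the same carbon would test. It is also unclear whether hydroxy on another carbon of that ring would do the same.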